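An Ester Tail Replaces an Amide Tail: Expected Cell Toxicity

The source may report more compounds than this note shows. Statements on the series, on what has been measured and on what is new or still open speak of the compounds shown alone.

Of the compounds shown here, three have been tested in a functional assay on MT4 cells (Homo sapiens); on this read-out higher numbers stand for lower toxicity in this test and lower numbers for higher toxicity in this test. Compound 1 `Cc1cn([C@@H]2O[C@@H]3COC4(O)CS(=O)(=O)O[C@@]34[C@H]2O[Si](C)(C)C(C)(C)C)c(=O)[nH]c1=O` gives 100000 nM. Compound 2 `Cc1cn([C@@H]2O[C@H](CO[Si](C)(C)C(C)(C)C)[C@@]3(OS(=O)(=O)C=C3NCCC(N)=O)[C@H]2O[Si](C)(C)C(C)(C)C)c(=O)n(C)c1=O` gives 20000 nM, the lowest of the two plain numbers, with compound 1 sitting at a higher number by a margin beyond the usual scatter. Compound 3 `Cc1cn([C@@H]2O[C@@H]3COC(=O)[C@]3(OS(C)(=O)=O)[C@H]2O)c(=O)[nH]c1=O` returns only a limit of the assay, >= 250000 nM, not a number.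

Compound 4 `COC(=O)CNC1=CS(=O)(=O)O[C@@]12[C@@H](CO[Si](C)(C)C(C)(C)C)O[C@@H](n1cc(C)c(=O)n(C)c1=O)[C@@H]2O[Si](C)(C)C(C)(C)C` has not yet been measured. It differs from compound 2 in one place: methoxycarbonyl in place of carbamoylmethyl on a saturated chain carbon bound to an amine nitrogen. The amine nitrogen and the rest of the molecule are unchanged.

Going by the values given here, no pair of measured compounds differing in a single place is available, so there is no measured step to lean on. The change is small in size and sits at the end of a side chain, so no step beyond the scatter is expected. The step from compound 2 to compound 4 in this assay is estimated as a 1.3-fold higher number from compound 2 to compound 4 (0.10 log units; within the scatter). Compound 4 is therefore expected to give about 25000 nM, most likely between 8000 nM and 80000 nM.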

Compound 4, half-maximal cytotoxic concentration: 105000 nM
Beside the measured number, compound 4's estimate is 4.2-fold (0.62 log units) below it; the whole stated range lies below it.
By their numbers in this assay, from the lowest: compound 2; then compounds 1 and 4 (each within the scatter of the next). At a limit, above all of these: compound 3.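

In this assay, methoxycarbonyl in place of carbamoylmethyl on a saturated chain carbon bound to an amine nitrogen gives a 5.3-fold higher number from compound 2 to compound 4 (0.72 log units; beyond the scatter). Going by these compounds alone, this is the first single-place step in the set, and it shows that the end of this side chain can shift the read-out beyond the scatter, towards lower toxicity in this test, even though the entering and leaving groups have the same count of heavy atoms. Compound 3 alone returns a limit of the assay and not a number, so compound 4 still lies on the measurable part of the scale: the limit of >= 250000 nM in this assay, at which 1 of the 4 values shown sits.

A single step cannot separate what the ester brings from what the departing amide takes away. As far as these compounds go, how a carboxylic acid, an amine or a longer chain at this place would read in this assay remains open.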